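The source may hold more compounds than are shown below. What is called first, only, known or untested is meant among the compounds shown, and "the series" means these compounds.

Measured compounds:
compound 1 `CCC(C)(C)Cc1c[nH]c(CCc2ccc(-c3ccncc3)cc2)n1` — 95 nM
compound 2 `CCC(C)(C)Cc1c[nH]c(CCc2ccc(-n3ccnn3)cc2)n1` — 93 nM
compound 3 `CCC(C)(C)Cc1c[nH]c(CCc2ccc(-c3cnccn3)cc2)n1` — 100 nM

In a functional assay on HEK293 cells for agonist activity at Bombesin receptor subtype-3 (Homo sapiens), read by luminescence and calcium flux, with a stated time of 10 min (on this read-out higher numbers stand for an effect only at larger amounts of compound and lower numbers for an effect already at smaller amounts), the three measured compounds sit close together; compound 1 has the second highest number of the three, and its steps to compound 2 a 1.0-fold lower number from compound 1 to compound 2 (0.01 log units; within the scatter) and to compound 3 a 1.1-fold higher number from compound 1 to compound 3 (0.02 log units; within the scatter) both fall within the scatter, as does the step between them a 1.1-fold higher number from compound 2 to compound 3 (0.03 log units; within the scatter).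

Compound 4 `CCC(C)(C)Cc1c[nH]c(CCc2ccc(-c3cccc(C#N)n3)cc2)n1` differs from compound 1 in one place: 6-cyanopyridin-2-yl in place of pyridin-4-yl on an aromatic carbon. Among the compounds with values here, the only comparable information is the three exchanges of the terminal aromatic ring on the same position, none of which moved the number beyond the scatter. Within the data shown here, the entering group carries a nitrile that no measured compound has, so some uncertainty remains. For compound 4 a step of a 1.3-fold higher number from compound 1 to compound 4 (0.10 log units; within the scatter) is expected, with an estimate of 120 nM in this assay, ranging from 40 nM to 400 nM.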

Compound 4, half-maximal effective concentration: 95 nM
For compound 4 the middle estimate is 1.3-fold (0.10 log units) above the measured one; measured number inside the range.
By their numbers in this assay, from the lowest: compounds 2, 1, 4 and 3 (each within the scatter of the next).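

In this assay this position also accepts 6-cyanopyridin-2-yl, with no change at the digits printed from compound 1 to compound 4 (within the scatter) and a 1.0-fold higher number from compound 2 to compound 4 (0.01 log units; within the scatter) and a 1.1-fold lower number from compound 3 to compound 4 (0.02 log units; within the scatter) all lying within the scatter. Within the data shown here, a nitrile, absent from the earlier compounds, and a larger entering group therefore leave the number unmoved here. No measurement available explains this result.

Still open, on these data alone, is whether an amine or a carboxylic acid on the terminal ring, in place of the nitrile, would also leave the number unmoved.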